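From compound 3 to compound 4: one added fluoro

The compounds below may be only part of what the source reports. "The series", "measured", "known", "first", "only" and "open" are said of these compounds alone.

compound 1 `O=[N+]([O-])c1cc(C(F)(F)F)cc([N+](=O)[O-])c1Oc1ccc(Br)cc1/C=N\OCc1ccccc1` gives 1180 nM
compound 2 `O=[N+]([O-])c1cc(C(F)(F)F)cc([N+](=O)[O-])c1Oc1ccc(Br)cc1/C=N\OCc1ccccc1F` gives 890 nM
compound 3 `O=[N+]([O-])c1cc(C(F)(F)F)cc([N+](=O)[O-])c1Oc1c(Br)cc(Br)cc1/C=N\OCc1ccccc1` gives 1480 nM

These three values come from a functional assay on HepG2 cells (Homo sapiens) for antiproliferative activity, read by MTT assay, with a stated time of 48 h (a higher number here means a weaker inhibitor, a lower number a stronger inhibitor), and they are all that is known so far. Compound 3 differs from compound 1 by bromo in place of hydrogen on an aromatic carbon, and a 1.3-fold higher number from compound 1 to compound 3 (0.10 log units; within the scatter) leaves compound 3 with no place of its own relative to compound 1.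

Compound 4 `O=[N+]([O-])c1cc(C(F)(F)F)cc([N+](=O)[O-])c1Oc1c(Br)cc(Br)cc1/C=N\OCc1ccccc1F` is still unmeasured. It is compound 3 with one change fluoro in place of hydrogen on an aromatic carbon and that change is fluoro in place of hydrogen on an aromatic carbon, turning benzyl to 2-fluorobenzyl.

Among the measured compounds shown here, one measured step bears directly on it. For the measured compounds named here, the same exchange gave a 1.3-fold lower number from compound 1 to compound 2 (0.12 log units; within the scatter) and that is the only guide to direction. It was taken on compound 1, so its carry-over to compound 3 is an assumption. In this assay a small drift towards a lower number is therefore expected, with nothing beyond the scatter. The estimated step is a 1.3-fold lower number from compound 3 to compound 4 (0.12 log units; within the scatter) and it is expected to stay within the scatter. Compound 4 is estimated at 1120 nM with an expected range from 700 nM to 1800 nM as its span.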

Compound 4, half-maximal inhibitory concentration: 1100 nM
The estimate for compound 4 lay 1.0-fold (0.01 log units) above the measured number; the range from low to high includes it.
By their numbers in this assay, from the lowest: compounds 2, 4, 1 and 3 (each within the scatter of the next).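

In this assay, among the compounds shown here, the change from benzyl to 2-fluorobenzyl, previously seen only on the core of compound 1, gives a 1.3-fold lower number from compound 3 to compound 4 (0.13 log units; within the scatter), and its two readings on separate cores agree: the same change on two cores in this assay, a 1.3-fold lower number (0.12 log units; within the scatter) from compound 1 to compound 2 and a 1.3-fold lower number (0.13 log units; within the scatter) from compound 3 to compound 4, 1.0-fold (0.01 log units) apart, within the scatter of two such steps The added bromo can now also be read on a second core, with a 1.2-fold higher number from compound 2 to compound 4 (0.09 log units; within the scatter), and it repeats in the same way: the same change on two cores in this assay, a 1.3-fold higher number (0.10 log units; within the scatter) from compound 1 to compound 3 and a 1.2-fold higher number (0.09 log units; within the scatter) from compound 2 to compound 4, 1.0-fold (0.01 log units) apart, within the scatter of two such steps Across these four compounds, neither change steps beyond the scatter on either core, and the size of each step shows no dependence on the other change.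

The compounds shown leave open whether a methoxy group, an amine or a carboxylic acid in place of the fluoro would give a step beyond the scatter. They also do not show whether fluoro on another carbon of this ring would behave in the same way.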